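The source may report more compounds than this note shows. Statements on the series, on what has been measured and on what is new or still open speak of the compounds shown alone.

Compound 1 `CN1CCN(c2ccc(Nc3ncc(Cl)c(NCc4ccccc4)n3)nc2)CC1`: 17300 nM
Compound 2 `CN1CCN(c2ccc(Nc3ncc(Cl)c(NCc4ccc(C(F)(F)F)cc4)n3)nc2)CC1`: 28400 nM
Compound 3 `Cc1ccc(Nc2nc(Nc3ccc(N4CCN(C)CC4)cn3)ncc2Cl)cc1`: 11400 nM

In a functional assay on MCF7 cells (Homo sapiens) for inhibition, read by CCK-8 assay, with a stated time of 48 h (on this read-out lower numbers stand for stronger inhibition of growth and higher numbers for weaker inhibition of growth), compound 3 gives 11400 nM and stands within the scatter on one side, showing a 1.5-fold lower number from compound 1 to compound 3 (0.18 log units; within the scatter), but clear of the scatter on the other, showing a 2.5-fold lower number from compound 2 to compound 3 (0.40 log units; beyond the scatter) as a modest gap. Compound 4 `Cc1cccc(Nc2nc(Nc3ccc(N4CCN(C)CC4)cn3)ncc2Cl)c1` differs from compound 3 in one place, (3-methylphenyl in place of 4-methylphenyl on a nitrogen on an aromatic ring), with 3-methylphenyl in place of 4-methylphenyl on a nitrogen on an aromatic ring. Among the compounds with values here, no measured step tests this exact exchange. The closest evidence, a 1.6-fold higher number from compound 1 to compound 2 (0.22 log units; within the scatter) alongside the small step already noted, gives no ground for a larger shift. The expected step is a 1.1-fold higher number from compound 3 to compound 4 (0.02 log units; within the scatter), so none beyond the scatter is anticipated. Compound 4 is estimated at 12000 nM, with an expected range from 6000 nM to 24000 nM as its bounds.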

Compound 4, concentration for 50% growth inhibition: 7160 nM
Compound 4: the middle estimate sits 1.7-fold (0.22 log units) above what was measured; measured number inside the range.
By their numbers in this assay, from the lowest: compounds 4, 3, 1 and 2 (each within the scatter of the next, the first and the last beyond it).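

In this assay, 3-methylphenyl in place of 4-methylphenyl on the nitrogen stays within the scatter (a 1.6-fold lower number from compound 3 to compound 4 (0.20 log units; within the scatter)), so this exchange alone does not separate the two compounds. Even so, compound 4 is the first compound here to clear the scatter against the benzyl compound (a 2.4-fold lower number from compound 1 to compound 4 (0.38 log units; beyond the scatter)), and its gap to the 4-(trifluoromethyl)benzyl compound is also beyond the scatter (a 4.0-fold lower number from compound 2 to compound 4 (0.60 log units; beyond the scatter)). No available evidence accounts for these differences.

The compounds shown leave open whether 3-methoxyphenyl or 3-chlorophenyl on that nitrogen would give a similar number, and whether a methyl on the benzyl group would behave as it does on the phenyl group.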